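A Cyano-Bearing Ring Replaces a Methoxy-Bearing Ring

The source may report more compounds than this note shows. Statements on the series, on what has been measured and on what is new or still open speak of the compounds shown alone.

Compound 1 (`CC/C(=C(/c1ccc(/C=C/C(=O)O)cc1)c1ccc2[nH]ncc2c1)c1ccccc1C#N`), compound 2 (`CC/C(=C(/c1ccc(/C=C/C(=O)O)cc1)c1ccc2[nH]ncc2c1)c1ccccc1S(C)(=O)=O`) and compound 3 (`CC/C(=C(/c1ccc(/C=C/C(=O)O)cc1)c1ccc2[nH]ncc2c1)c1ccccc1OC`) share one core and differ in a single group on an aromatic ring: cyano, methylsulfonyl or methoxy. In a functional assay on MCF7 cells (Homo sapiens) for cytotoxicity, read by CellTiter-Glo, with a stated time of 5 days (a higher number here means a weaker inhibitor, a lower number a stronger inhibitor), compound 1 gives 12 nM, compound 2 gives 70 nM and compound 3 gives 25 nM. Compound 3 therefore holds the second highest of the three numbers.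

Compound 4 (`CC/C(=C(/c1ccc(/C=C/C(=O)O)cc1)c1ccc2[nH]ncc2c1)c1ccc(C#N)cc1C`) has not been measured yet. It keeps the core, but a whole ring is exchanged: 4-cyano-2-methylphenyl in place of 2-methoxyphenyl on a double-bonded chain carbon bound to a double-bonded chain carbon and a saturated chain carbon. In words, 4-cyano-2-methylphenyl stands in place of 2-methoxyphenyl on a double-bonded chain carbon bound to a double-bonded chain carbon and a saturated chain carbon.

Within the data shown here, three measured steps bear on this change, all modest but beyond the scatter: a 5.8-fold higher number from compound 1 to compound 2 (0.77 log units; beyond the scatter), a 2.8-fold lower number from compound 2 to compound 3 (0.45 log units; beyond the scatter) and a 2.1-fold higher number from compound 1 to compound 3 (0.32 log units; beyond the scatter). The last is the closest guide, as it links a cyano-bearing ring to a methoxy-bearing one. Read backwards, it hints at a slightly lower number for a cyano-bearing ring. Among the measured compounds shown here, no measured compound carries the added methyl group, so this guide is weak.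

The expected change is small and within the scatter, in the lower direction: a 1.4-fold lower number from compound 3 to compound 4 (0.14 log units; within the scatter). For compound 4 the estimated value in this assay is 18 nM, with an expected range from 6 nM to 55 nM.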

Compound 4, half-maximal inhibitory concentration: 5 nM
The estimate for compound 4 lay 3.6-fold (0.56 log units) above the measured number; measured number outside the range, below it.
By their numbers in this assay, from the lowest: compound 4; then compound 1; then compound 3; then compound 2.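

At this place on the double-bonded chain carbon, a ring bearing two groups reaches a lower number in this assay than any of the three rings bearing one group, so those earlier rings did not mark the limit of what this position allows. Among these compounds, the change is clear against the 2-methoxyphenyl ring, with a 5.0-fold lower number from compound 3 to compound 4 (0.70 log units; beyond the scatter) here, and greater against the 2-(methylsulfonyl)phenyl ring, with a 14-fold lower number from compound 2 to compound 4 (1.15 log units; beyond the scatter) as the only large step in the set. Even the 2-cyanophenyl ring, the lowest of the earlier three, is passed, with a 2.4-fold lower number from compound 1 to compound 4 (0.38 log units; beyond the scatter) on record, which leaves compound 4 with the lowest number of the four.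

As far as these compounds go, compound 4 differs from compound 1 in two ways within the one ring, an added methyl group and a changed place for the nitrile, so the share of each remains unknown, and the simpler rings 2-methylphenyl and 4-cyanophenyl would be needed to separate them. No measurement at hand gives a reason for this lower number.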